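Hydroxyl to methoxy on the N-substituent chain

A few compounds are considered here, and "the series" means these few. Any claim that something is new, unique, unknown or untested is made for them only; others in the source may bear on it.

Measured compounds:
compound 1 `CCCn1c(=O)n(CC(=O)O)c(=O)c2[nH]cnc21` with > 200000 nM
compound 2 `CCCn1c(=O)n(CCO)c(=O)c2[nH]cnc21` with 50000 nM
compound 3 `CCCn1c(=O)n(CCCO)c(=O)c2[nH]cnc21` with 12000 nM

The three compounds share one core and differ only in the chain on the ring nitrogen. In an assay on Cerebral cortex for binding affinity to adenosine receptor A1 (Cavia porcellus), read by radioligand binding (a higher number here means a weaker inhibitor, a lower number a stronger inhibitor), compound 1 gives a limit, > 200000 nM, and no number. Compound 2 gives 50000 nM in this assay. Compound 3 gives 12000 nM and so stands lowest of the two numbers, with compound 2 as its nearest neighbour.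

The steps run in one direction: an at least 4.0-fold lower number from compound 1 to compound 2 (0.60 log units; beyond the scatter); an at least 16-fold lower number from compound 1 to compound 3 (1.22 log units; beyond the scatter); a 4.2-fold lower number from compound 2 to compound 3 (0.62 log units; beyond the scatter). Each involves the chain terminus, and the last one, a small growth of the chain, is modest.

Compound 4 `CCCn1c(=O)n(CCOC)c(=O)c2[nH]cnc21` is not yet measured. It differs from compound 3 by methoxy in place of hydroxymethyl on a saturated chain carbon, two bonds along the chain from an aromatic nitrogen. The measured steps bear on this only loosely, since none of them exchanges a donor for a bare acceptor at this place. The chain-extension step is the closest guide, and a step of comparable size or none beyond the scatter is expected, leaning weaker as the donor is lost. Compound 4 is therefore expected to give 15000 nM, between 4000 nM and 60000 nM. The expected step is a 1.3-fold higher number from compound 3 to compound 4 (0.10 log units; within the scatter).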

Compound 4, inhibition constant: 2500 nM
Estimate against measurement, compound 4: 6.0-fold (0.78 log units) above; the whole stated range lies above it.
By their numbers in this assay, from the lowest: compound 4; then compound 3; then compound 2. At a limit, above all of these: compound 1.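

In this assay the exchange of hydroxymethyl for methoxy, which keeps the same atoms but removes the hydrogen-bond donor at this place on the chain, gives a 4.8-fold lower number from compound 3 to compound 4 (0.68 log units; beyond the scatter) and so shows that a donor here is not needed for binding in this small series. Placing methyl on the oxygen of the shorter alcohol goes further, giving a 20-fold lower number from compound 2 to compound 4 (1.30 log units; beyond the scatter) and marking the first change among these compounds that caps the terminal oxygen. Against the carboxy chain the step is an at least 80-fold lower number from compound 1 to compound 4 (1.90 log units; beyond the scatter) and is only a bound, since compound 1 gives a limit: the limit of > 200000 nM in this assay, at which 1 of the 4 values shown sits.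

No measurement shown accounts for this gain. As far as these compounds go, whether an ethoxy group, a longer chain ending in methoxy or a terminal amine would lower the number further remains open.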